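This account rests on a few compounds, and the source may have more. Where it says the series, first, only, none or still open, it means among the compounds named here.

Measured so far:
Compound 1 `CCCOc1cccc(/C=N/n2c(-c3ccccc3)nc3ccccc3c2=O)c1`, which in a functional assay on the whole organism (strain albino CF-1) with Mus musculus as the target, in the maximal electroshock model, with a stated time of 4 h (on this read-out higher numbers stand for an effect only at larger amounts of compound and lower numbers for an effect already at smaller amounts), gives 30 mg/kg.
Compound 2 `C=CCOc1cccc(/C=N/n2c(-c3ccccc3)nc3ccccc3c2=O)c1`, which in this assay gives 300 mg/kg.

Compound 2 stands at the highest of the two numbers measured in this assay, meaning it needs the larger amount of the two to show an effect. Among the measured compounds shown here, its nearest neighbour is compound 1, and the single measured step, a 10-fold higher number from compound 1 to compound 2 (1.00 log units; beyond the scatter), separates them.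

Compound 3 `O=c1c2ccccc2nc(-c2ccccc2)n1/N=C/c1cccc(OCc2ccccc2)c1` is the next compound to be measured. It differs from compound 2 in one place: phenyl in place of vinyl on a saturated chain carbon bound to an oxygen on an aromatic ring.

For the measured compounds named here, only one measured step touches the same place, the step from compound 1 to compound 2, where a 10-fold higher number from compound 1 to compound 2 (1.00 log units; beyond the scatter). That step concerns a different group entering than the one here, so it gives direction only loosely: swapping one small group for another at this place moved the number by a modest amount. Phenyl is a larger group than either of those, and no measured compound carries it at this place, so the expectation is broad. For compound 3 the number in this assay is expected to be 100 mg/kg, with a range from 30 mg/kg to 300 mg/kg, which means an expected step of a 3.0-fold lower number from compound 2 to compound 3 (0.48 log units; beyond the scatter).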

Compound 3, minimum effective dose: 300 mg/kg
The estimate for compound 3 lay 3.0-fold (0.48 log units) below the measured number, within the range that was stated.
By their numbers in this assay, from the lowest: compound 1; then compounds 2 and 3 (each within the scatter of the next).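

In this assay, phenyl in place of vinyl on a saturated chain carbon bound to an oxygen on an aromatic ring gives no change at the digits printed from compound 2 to compound 3 (within the scatter), so the move from a group of 2 heavy atoms with a double bond to an aromatic ring of 6 heavy atoms leaves the two compounds indistinguishable on this read-out. Phenyl in place of ethyl gives a 10-fold higher number from compound 1 to compound 3 (1.00 log units; beyond the scatter), a gap of the same size as the one already seen with vinyl, so among the three compounds shown, the ethyl compound alone stands apart, with the effect appearing at the smallest amount. No supporting measurement is available to explain why ethyl differs from the other two groups at this place.

The compounds shown leave open whether the ethyl result reflects a wider preference for saturated chains, which a longer chain such as butyl or a ring such as cyclopropyl at the same place would help test. They also leave open how a chain ending in an amine or a carboxylic acid would behave here.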